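Amine Variation Three Bonds from the Aryl Ether Oxygen

The source may report more compounds than this note shows. Statements on the series, on what has been measured and on what is new or still open speak of the compounds shown alone.

Measured so far:
compound 1 `CC(=O)Oc1ccc(C(=O)Nc2cc3ccc(OCCC4CCCCN4)c(C)c3oc2=O)cc1CC=C(C)C` — 710 nM
compound 2 `CC(C)=CCc1cc(C(=O)Nc2cc3ccc(OCCCN(C)C(C)C)c(C)c3oc2=O)ccc1O` — 1050 nM
compound 3 `COC(=O)CNCCCOc1ccc2cc(NC(=O)c3ccc(O)c(CC=C(C)C)c3)c(=O)oc2c1C` — 2820 nM

In a functional assay on MCF7 cells (Homo sapiens) for antiproliferative activity (on this read-out higher numbers stand for weaker inhibition and lower numbers for stronger inhibition), compound 2 holds the second highest of the three numbers. Its nearest neighbour is compound 1, whose number lies within the scatter of that of compound 2; its furthest is compound 3, beyond the scatter.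

Compound 4 `CC(C)=CCc1cc(C(=O)Nc2cc3ccc(OCCCNC(C)(C)c4ccccc4)c(C)c3oc2=O)ccc1O` is the next compound in the set. It differs from compound 2 in one place: (1-methyl-1-phenylethyl)amino in place of isopropyl(methyl)amino on a saturated chain carbon, three bonds along the chain from an oxygen on an aromatic ring.

Going by the values given here, one measured step bears on this position. Replacing isopropyl(methyl)amino by ((methoxycarbonyl)methyl)amino gives a 2.7-fold higher number from compound 2 to compound 3 (0.43 log units; beyond the scatter). Compound 1, with a ring-bearing amine at the same place, sits within the scatter of compound 2, so the two amines measured there point in different directions and neither carries a phenyl ring. Among the compounds with values here, no measured step reaches the size of the group entering in compound 4.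

On this footing the step in this assay from compound 2 to compound 4 is expected to be small, at most modest, with a slight lean toward a lower number. Compound 4 is estimated at 850 nM, with a range of 350 nM to 2100 nM. The estimate means an expected step of a 1.2-fold lower number from compound 2 to compound 4 (0.09 log units; within the scatter).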

Compound 4, half-maximal inhibitory concentration: 1070 nM
The estimate for compound 4 lay 1.3-fold (0.10 log units) below the measured number, and the stated range covers the measured number.
By their numbers in this assay, from the lowest: compounds 1, 2 and 4 (each within the scatter of the next); then compound 3.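

In this assay, (1-methyl-1-phenylethyl)amino in place of isopropyl(methyl)amino gives a 1.0-fold higher number from compound 2 to compound 4 (0.01 log units; within the scatter), so the numbers of the two compounds lie within the scatter of each other even though the entering group brings a six-membered aromatic ring and a hydrogen-bond donor. The higher number of compound 3 is therefore not shared by every amine carrying an amine hydrogen at this place: 1-methyl-1-phenylethyl in place of (methoxycarbonyl)methyl on an amine nitrogen gives a 2.6-fold lower number from compound 3 to compound 4 (0.42 log units; beyond the scatter), a modest step, and the amine hydrogen present in both compound 3 and compound 4 does not by itself go with the higher number. Nothing on hand explains why the ((methoxycarbonyl)methyl)amino group stands apart from the other two amines.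

On these data alone, it remains open whether the higher number of compound 3 belongs to the methyl ester or to the rest of that group, a question that the matching carboxylic acid or a primary amide would address. As far as these compounds go, it also remains open how much further variation this position tolerates, for instance with a benzylamine, a piperazine or a longer chain ahead of the amine.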